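The source may report more compounds than this note shows. Statements on the series, on what has been measured and on what is new or still open speak of the compounds shown alone.

Compound 1 `N#Cc1ccc(NC(=O)Nc2ccc(F)c(C(F)(F)F)c2)cc1`: 3.8
Compound 2 `O=C(Nc1ccnc(C(F)(F)F)c1)Nc1ccc(F)c(C(F)(F)F)c1`: 3.8
Compound 3 `O=C(Nc1ccc(F)c(C(F)(F)F)c1)Nc1cnccn1`: 3

In a physicochemical assay for lipophilicity, read by HPLC, measured as octanol-water partition, at pH 7.2 (a higher number here means a more lipophilic compound, a lower number a more polar compound), compound 3 stands lowest of the three measured compounds; compound 1 and compound 2 both lie higher, each by a gap beyond the usual scatter, and those two sit within the scatter of each other. Compound 4 `O=C(Nc1cccnc1)Nc1ccc(F)c(C(F)(F)F)c1` has not yet been measured. It differs from compound 3 in one place: pyridin-3-yl in place of pyrazin-2-yl on an amide-type nitrogen. Going by the values given here, no step between measured compounds covers this particular change, so the expectation rests on the change itself. A rise in this assay beyond the scatter is expected for compound 4, the step being estimated at a number 0.70 log units higher from compound 3 to compound 4 (beyond the scatter). Compound 4 is therefore expected to give 3.7, within a range from 3.3 to 4.1.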

Compound 4, distribution coefficient: 3
The estimate for compound 4 lay 0.70 log units above the measured number; the measured number lies below the stated range.
By their numbers in this assay, from the lowest: compounds 3 and 4 (each within the scatter of the next); then compounds 1 and 2 (each within the scatter of the next).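

Going by these compounds alone, the step from pyrazin-2-yl to pyridin-3-yl on an amide-type nitrogen is the first single-place comparison at this position, and in this assay it reads no change at the digits printed from compound 3 to compound 4 (within the scatter) for this exchange. The earlier compounds shown here offered no such step, and this one shows that, on this shared core, going from two ring nitrogens to one need not move the read-out. Nothing at hand explains this result. Going by these compounds, whether this holds for other rings at this position stays open. So does how an aliphatic amine such as morpholine or a carboxylic acid on the ring would read in this assay here.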